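Adding one methyl to compound 1

The source may report more compounds than this note shows. Statements on the series, on what has been measured and on what is new or still open speak of the compounds shown alone.

Compound 1 `CC(C)C[C@H](NC(=O)CSc1cc(NS(=O)(=O)c2cccs2)c2ccccc2c1O)B(O)O` has been tested in a functional assay on MCF7 cells (Homo sapiens) for antiproliferative activity, read by sulforhodamine B assay, with a stated time of 72 h (on this read-out lower numbers stand for stronger inhibition and higher numbers for weaker inhibition), where compound 1 gives 9450 nM. Among the compounds with values here, this is the only number available for it, as one further entry for compound 1 carries no single number. In this assay, compound 2 `CC(C)C[C@H](NC(=O)C(C)Sc1cc(NS(=O)(=O)c2ccc(Cl)cc2)c2ccccc2c1O)B(O)O` gives 10100 nM; 10700 nM (2 entries), which lies within the usual scatter of the value of compound 1. Compound 3 `CC(C)C[C@H](NC(=O)C(C)Sc1cc(NS(=O)(=O)c2cccs2)c2ccccc2c1O)B(O)O` has not yet been measured. It differs from compound 1 by methyl in place of hydrogen on a saturated chain carbon bound to a carbonyl carbon and a sulfur, with methyl in place of hydrogen on a saturated chain carbon bound to a carbonyl carbon and a sulfur. Within the data shown here, no measured pair of compounds isolates a single change, so there is no direct precedent for the size of this step. The expectation therefore rests on the values already seen, with compound 1 at 9450 nM and compound 2 at 10100 nM; 10700 nM (2 entries). No shift beyond the scatter is expected in this assay, in either direction. The expected change is a 1.1-fold higher number from compound 1 to compound 3 (0.02 log units; within the scatter). For compound 3 the estimated value is 10000 nM, with an expected range from 5000 nM to 20000 nM.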

Compound 3, half-maximal inhibitory concentration: 14700 nM
For compound 3 the middle estimate is 1.5-fold (0.17 log units) below the measured one; the measured number falls inside the stated range.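

Methyl in place of hydrogen on a saturated chain carbon bound to a carbonyl carbon and a sulfur now has a direct reading in this assay, where the change gives a 1.6-fold higher number from compound 1 to compound 3 (0.19 log units; within the scatter). This is the first pair of compounds shown that isolates a single change, and it places this position among those where methyl can replace hydrogen without a step that stands clear of the scatter of this assay, so the reading gives no sign that this carbon matters to the antiproliferative read-out, at least for a group of this size. How closely separate readings agree in this assay can be judged from one compound, which gives a sense of how little weight a step of this size can carry: the several entries of compound 2 in this assay, 10100 nM; 10700 nM (2 entries)

The compounds shown leave open whether a longer chain, an amine or a carboxylic acid on the same saturated chain carbon would move the number beyond the scatter. Equally open, going by these compounds, is whether a step of this size would also apply on the core of compound 2.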